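The source may hold more compounds than are shown below. What is called first, only, known or untested is meant among the compounds shown, and "the series" means these compounds.

Measured compounds: compound 1 `COc1ccc(Cn2c(C(=O)O)c(CNCc3cc(OC)ccc3O)c3ccc(C)cc32)cc1` gives > 50000 nM in a functional assay on Bel-7402 cells (Homo sapiens) for antiproliferative activity, read by MTT assay, with a stated time of 72 h; on this read-out higher numbers stand for weaker inhibition and lower numbers for stronger inhibition; compound 2 `COc1ccc(Cn2c(C(=O)O)c(CNCc3cccc(OC)c3)c3ccc(C)cc32)cc1` gives 9830 nM; compound 3 `COc1cccc(CNCc2c(C(=O)O)n(Cc3ccccc3)c3cc(C)ccc23)c1` gives 12500 nM.

The value given for compound 1 is a limit of this assay, not a number, as stated in the limit of > 50000 nM in this assay, at which 1 of the 3 values shown sits. The cores of compound 2 and compound 3 differ by hydrogen in place of methoxy on an aromatic carbon, and the step of a 1.3-fold higher number from compound 2 to compound 3 (0.10 log units; within the scatter) lies within the scatter. The change hydroxy in place of hydrogen on an aromatic carbon gave the step of an at least 5.0-fold higher number from compound 2 to compound 1 (0.70 log units; beyond the scatter). Compound 4 `COc1cccc(CNCc2c(C(=O)O)n(Cc3ccc(O)cc3)c3cc(C)ccc23)c1` carries the same kind of change, (hydroxy in place of hydrogen on an aromatic carbon), but on the other benzyl, para to a large group, rather than ortho to a large group and para to a methoxy group. Because an at least 5.0-fold higher number from compound 2 to compound 1 (0.70 log units; beyond the scatter) weakened compound 1, compound 4 is expected to weaken too, giving the estimated step of a 2.4-fold higher number from compound 3 to compound 4 (0.38 log units; beyond the scatter). Compound 4 is estimated at 30000 nM, between 10000 nM and 90000 nM.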

Compound 4, half-maximal inhibitory concentration: > 50000 nM
Compound 4 ended at the assay's limit; the forecaster's own chance of this, stated with the estimate: 40%; at least 1.6-fold (0.22 log units) between middle value and limit.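

In this assay, hydroxy in place of hydrogen on the benzyl gave an at least 4.0-fold higher number from compound 3 to compound 4 (0.60 log units; beyond the scatter), and hydrogen in place of methyl on the oxygen of the same ring gave an at least 5.0-fold higher number from compound 2 to compound 4 (0.70 log units; beyond the scatter). Hydroxy on an aromatic carbon thus weakened inhibition on both cores, though on a different ring of each: the same change on two cores in this assay, an at least 5.0-fold higher number (0.70 log units; beyond the scatter) from compound 2 to compound 1 and an at least 4.0-fold higher number (0.60 log units; beyond the scatter) from compound 3 to compound 4; the limit leaves it open whether they differ. Neither the full size of the change nor any difference between the cores can be read, as compound 1 and compound 4 both stand at a limit of the assay and not at a number: the limit of > 50000 nM in this assay, at which 2 of the 4 values shown sit.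

The compounds shown leave open whether an amine or a fluorine in place of that hydroxy would keep inhibition. They also leave open how a methyl ester in place of the carboxylic acid would act on the shared core.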